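Halogen swap on the benzylsulfanyl arm: chloro to fluoro

A few compounds are considered here, and "the series" means these few. Any claim that something is new, unique, unknown or untested is made for them only; others in the source may bear on it.

Three compounds of this series have been run in a functional assay on the whole organism (artery, strain albino) with Rattus norvegicus as the target, with a stated time of 300 min, at a dose of 10 mg/kg by the oral route; on this read-out lower numbers stand for less inhibition and higher numbers for more inhibition at the one dose given (going by the name of the read-out). Compound 1 `CC1=C(C(=O)Nc2ccc(F)cc2)C(c2ccc([N+](=O)[O-])cc2)N=C(SCc2ccc(Cl)cc2)N1` gives 37.9% in this assay. Compound 2 `CC1=C(C(=O)Nc2ccc(F)cc2)C(c2ccc([N+](=O)[O-])cc2)N=C(SCc2ccc(F)cc2)N1` gives 30.3%. Compound 3 `CC1=C(C(=O)Nc2ccc([N+](=O)[O-])cc2)C(c2ccc(Br)cc2)N=C(SCc2ccc(Cl)cc2)N1` gives 37.9%, level with compound 1 at the digits recorded, and together these two are the highest of the three numbers, while the gap to compound 2 stays within the scatter.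

Compound 1 and compound 2 differ in one place:

fluoro in place of chloro on an aromatic carbon

This change gave a number 7.6 percentage points lower from compound 1 to compound 2 (within the scatter), a shift that lies within the scatter and so cannot be read as a real loss.

Compound 3 and compound 1 differ in more than one place; how their two cores differ is not broken down here.

Compound 4 `CC1=C(C(=O)Nc2ccc([N+](=O)[O-])cc2)C(c2ccc(Br)cc2)N=C(SCc2ccc(F)cc2)N1` has not been measured in this assay. Against compound 3 it carries the same change, at the same kind of place:

fluoro in place of chloro on an aromatic carbon

Among the compounds with values here, with only one earlier instance of this change to go on, the expectation for the step from compound 3 to compound 4 is a number 6.9 percentage points lower from compound 3 to compound 4 (within the scatter), resting on the step from compound 1 to compound 2 of a number 7.6 percentage points lower from compound 1 to compound 2 (within the scatter). Compound 4 is therefore estimated to give 31% in this assay, with an expected range from 20% to 42%. Within the data shown here, the range is wide because the single precedent of a number 7.6 percentage points lower from compound 1 to compound 2 (within the scatter) itself sits inside the scatter.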

Compound 4, a percentage reported as inhibition, in the whole organism at one dose (the size of the read-out at that dose, not a potency): 34.4%
The estimate for compound 4 lay 3.4 percentage points below the measured number; low and high end bracket the measured number.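

In this assay, the change from (4-chlorobenzyl)sulfanyl to (4-fluorobenzyl)sulfanyl on the core of compound 3 gives a number 3.5 percentage points lower from compound 3 to compound 4 (within the scatter), and the comparison with the core of compound 1 reads: the same change on two cores in this assay, a number 7.6 percentage points lower (within the scatter) from compound 1 to compound 2 and a number 3.5 percentage points lower (within the scatter) from compound 3 to compound 4, 4.1 percentage points apart, within the scatter of two such steps

The swap therefore carries across these two cores only in a limited sense: on neither core does it move the read-out beyond the scatter, and the size of the step does not measurably depend on which of the two cores bears it. This does not show that chloro and fluoro differ at this place, nor that they are truly equivalent, and two matched pairs in a single assay at one dose give no general rule for the series.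

The compounds shown leave open whether a group other than these two halogens on the benzyl ring, such as a methoxy, a trifluoromethyl, a nitrile or a carboxylic acid, would produce a step beyond the scatter. Also open, going by these compounds, are the plain unsubstituted benzyl arm, a longer alkyl chain on the sulfur, and an amine carried on that arm.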